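The compounds below may be only part of what the source reports. "The series", "measured", "known", "first", "only" and "open" are said of these compounds alone.

Compound 1 `Cc1oc(-c2c(C)c(C)c(C)c(C)c2C)nc1CN1CCC(C(=O)NCCCN2C[C@H](C)C[C@H](C)C2)CC1` and compound 2 `Cc1ccccc1-c1nc(CN2CCC(C(=O)NCCCN3CCCCC3)CC2)c(C)o1` share a core carrying an aryl group and a piperidine amide chain, and both have been examined in a physicochemical assay for permeability, using PAMPA; a higher number here means that the compound crosses the layer faster, a lower number that the compound crosses the layer more slowly. Compound 1 gives 455 10^-6 cm/s in this assay, while compound 2 gives 34.5 10^-6 cm/s. Compound 1 therefore stands highest of the two numbers, and its nearest neighbour, compound 2, sits well apart from it, beyond the usual scatter of such measurements.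

Compound 3 `Cc1ccc(-c2nc(CN3CCC(C(=O)NCCCN4C[C@H](C)C[C@H](C)C4)CC3)c(C)o2)cc1` has not yet been measured in this assay. It differs from compound 1 in one place: 4-methylphenyl in place of 2,3,4,5,6-pentamethylphenyl on an aromatic carbon. Compound 3 keeps the dimethylpiperidine end of the chain that compound 1 carries, so the change is confined to the aryl group alone.

Within the data shown here, no step between two measured compounds isolates this exact change. The two measured values, 455 10^-6 cm/s for compound 1 and 34.5 10^-6 cm/s for compound 2, frame the question without settling it. A moderate downward step is expected for compound 3, a 3.0-fold lower number from compound 1 to compound 3 (0.48 log units; beyond the scatter), larger than the scatter but short of the gap to compound 2. Compound 3 is therefore estimated at 150 10^-6 cm/s, within a range of 60 10^-6 cm/s to 400 10^-6 cm/s.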

Compound 3, apparent permeability: 274 10^-6 cm/s
Beside the measured number, compound 3's estimate is 1.8-fold (0.26 log units) below it; low and high end bracket the measured number.
By their numbers in this assay, from the lowest: compound 2; then compounds 3 and 1 (each within the scatter of the next).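

With 4-methylphenyl in place of 2,3,4,5,6-pentamethylphenyl on an aromatic carbon, this assay gives a 1.7-fold lower number from compound 1 to compound 3 (0.22 log units; within the scatter), so the two compounds cannot be told apart by this read-out. Compounds 1 and 2 differ in more than one place, so they could not speak to the aryl group alone; this pair shows that, with the dimethylpiperidine end of the chain held constant, an aryl group of 11 heavy atoms and one of 7 heavy atoms, both all carbon, give numbers within the scatter of each other at this position, next to the ring nitrogen and next to the ring oxygen. No measurement at hand accounts for this result or bears on what lies behind it.

The compounds shown leave open whether an aryl group carrying atoms other than carbon, such as a methoxy group, an amine or a carboxylic acid, would stay as close to compound 1 at this position. They also leave open whether the same exchange of aryl groups would give a step of similar size on a chain ending in the plain piperidine of compound 2.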